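The compounds below may be only part of what the source reports. "The series", "measured", "known", "first", "only" and "open" are said of these compounds alone.

Measured compounds:
compound 1 `N#Cc1c(N)nc(SCC(N)=O)c(C#N)c1-c1ccc(OCC2CC2)cc1`: 8%
compound 2 `N#Cc1c(N)nc(SCc2csc(N)n2)c(C#N)c1-c1ccc(OCC2CC2)cc1`: 1%

In an assay on CHO cells for displacement of a labelled ligand from adenosine receptor A3 (Homo sapiens), read by scintillation counting, with a stated time of 120 min, tested at 1 uM (on this read-out higher numbers stand for more inhibition at the one concentration tested (going by the name of the read-out) and lower numbers for less inhibition), compound 1 gives 8% and compound 2 gives 1%. Compound 1 has the higher of the two numbers, but the step of a number 7 percentage points lower from compound 1 to compound 2 (within the scatter) is within the scatter, so the two cannot be told apart; both show little displacement of the labelled ligand at the single concentration tested.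

The next compound is compound 3 `N#Cc1c(N)nc(SCc2ncn[nH]2)c(C#N)c1-c1ccc(OCC2CC2)cc1`. Its difference from compound 1 is 1H-1,2,4-triazol-5-yl in place of carbamoyl on a saturated chain carbon bound to a sulfur. Going by the values given here, only one measured step bears on this: from compound 1 to compound 2 a carbamoyl on the same chain carbon was exchanged for another five-membered aromatic ring, and that step, a number 7 percentage points lower from compound 1 to compound 2 (within the scatter), stayed inside the scatter. With a single step as guide, and both measured numbers lying near the bottom of the scale, no movement beyond the scatter is expected in this assay for this exchange either.

The estimate for compound 3 is therefore 5%, with a range from -10% to 20%, which corresponds to an expected step of a number 3 percentage points lower from compound 1 to compound 3 (within the scatter).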

Compound 3, a percentage reported as inhibition, at one concentration (the size of the read-out at that concentration, not a potency): 1%
The estimate for compound 3 lay 4 percentage points above the measured number; measured number inside the range.
By their numbers in this assay, from the lowest: compounds 2, 3 and 1 (each within the scatter of the next).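

In this assay, putting 1H-1,2,4-triazol-5-yl in place of carbamoyl gives a number 7 percentage points lower from compound 1 to compound 3 (within the scatter), so a second five-membered aromatic ring on the saturated chain carbon bound to a sulfur, this one with 3 hetero atoms, also stays within the scatter of the carbamoyl compound. The two rings cannot be told apart either, as exchanging 2-amino-1,3-thiazol-4-yl for 1H-1,2,4-triazol-5-yl gives no change at the digits printed from compound 2 to compound 3 (within the scatter). Three different groups at this place therefore give numbers that all lie within the scatter of one another and near the bottom of the scale, and nothing measured here speaks to why that is so.

From the compounds shown here alone, whether a group of another kind at this place, such as a carboxylic acid, a simple amine or a longer chain ending in a phenyl ring, would move the number beyond the scatter remains open. Going by these compounds, a reading at one concentration is also not a potency, and how these three compounds would compare at higher concentrations stays open as well.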